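From oxan-4-yl to 4-cyanophenyl

This account rests on a few compounds, and the source may have more. Where it says the series, first, only, none or still open, it means among the compounds named here.

Measured in a functional assay on A2780 cells (Homo sapiens) for antiproliferative activity, read by CellTiter-Glo, with a stated time of 4 days; on this read-out lower numbers stand for stronger inhibition and higher numbers for weaker inhibition:
Compound 1 `Nc1ccc(CNC(=O)Nc2ccc(CN3C(=O)c4ccccc4C3=O)cc2)cn1`: 7 nM
Compound 2 `CC[C@H](NC(=O)c1ccccc1)c1ccc(NC(=O)[C@H]2C[C@@H]2c2cccnc2)cc1`: 43 nM
Compound 3 `C[C@H](NC(=O)C1CCOCC1)c1ccc(NC(=O)[C@H]2C[C@@H]2c2cccnc2)cc1`: 3 nM

Compound 3, at 3 nM, holds the lowest number of the three, beyond the scatter from both compound 1 and compound 2. Compound 4 `C[C@H](NC(=O)c1ccc(C#N)cc1)c1ccc(NC(=O)[C@H]2C[C@@H]2c2cccnc2)cc1` has not yet been measured. It carries 4-cyanophenyl in place of oxan-4-yl on a carbonyl carbon. Going by the values given here, no step between measured compounds speaks directly to this change. Among the compounds with values here, the only hint is compound 2, which also has an aromatic ring on a carbonyl carbon, differs elsewhere too, and gives 43 nM. A moderate step to a higher number is expected in this assay, estimated as a 4.0-fold higher number from compound 3 to compound 4 (0.60 log units; beyond the scatter). For compound 4 the estimated value is 12 nM, with an expected range from 4 nM to 40 nM.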

Compound 4, half-maximal inhibitory concentration: 4 nM
Estimate against measurement, compound 4: 3.0-fold (0.48 log units) above, within the range that was stated.
By their numbers in this assay, from the lowest: compounds 3, 4 and 1 (each within the scatter of the next, the first and the last beyond it); then compound 2.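

In this assay the step at this carbonyl carbon is a 1.3-fold higher number from compound 3 to compound 4 (0.12 log units; within the scatter) and lies within the scatter. On this shared core, then, a six-membered aromatic ring of carbon only, bearing a nitrile, stands in for a six-membered non-aromatic ring with no measurable change in the number. Nothing available explains why the two groups read alike. Still open, from the compounds shown here alone, is whether the nitrile matters on the aromatic ring, and how an amine such as piperidin-4-yl or a carboxylic acid would read on this carbonyl carbon.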